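Swapping a Methylsulfonyl for an Aryl Group on an Oxazole

The source may report more compounds than this note shows. Statements on the series, on what has been measured and on what is new or still open speak of the compounds shown alone.

Of the compounds shown here, two have been measured in an assay on HEK-293T cells for inhibition of diacylglycerol lipase-alpha (Homo sapiens), read by colorimetric assay; a lower number here means a stronger inhibitor, a higher number a weaker inhibitor. Compound 1, `O=C(CCCCCc1ccccc1)c1nc2ccc(Br)cc2o1`, gives 5890 nM in this assay. Compound 2, `CS(=O)(=O)c1cnc(C(=O)CCCCCCc2ccccc2)o1`, gives only > 10000 nM in this assay, which is a limit of the measurement rather than a number, as the limit of > 10000 nM in this assay, at which 1 of the 2 values shown sits, records. For the measured compounds named here, compound 2 therefore stands at the weak end of what the two values show, while compound 1 is the only one with a measured number.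

The next compound, compound 3, `COc1ccc(-c2cnc(C(=O)CCCCCCc3ccccc3)o2)cc1`, has not been measured. It differs from compound 2 in one place: 4-methoxyphenyl in place of methylsulfonyl on an aromatic carbon. Going by the values given here, because no step between measured compounds is known, the size of this change can only be estimated from what compound 2 shows. Compound 3 is expected to move from the limit toward a measurable value, with a step of an at least 3.3-fold lower number from compound 2 to compound 3 (0.52 log units; beyond the scatter) in this assay. The estimate for compound 3 in this assay is 3000 nM, with a range from 500 nM to 15000 nM.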

Compound 3, half-maximal inhibitory concentration: > 10000 nM
Compound 3: a limit, no number (the forecaster's own chance of this, stated with the estimate: 25%); middle value at least 3.3-fold (0.52 log units) from the limit.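

For the compounds shown here, compound 2 and compound 3 both give only a limit and not a number in this assay, so no step between them can be read: the limit of > 10000 nM in this assay, at which 2 of the 3 values shown sit. The compounds shown leave open how far each lies from that limit, and whether methylsulfonyl or 4-methoxyphenyl on that aromatic carbon gives the stronger inhibitor.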